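The source may hold more compounds than are shown below. What is called first, only, known or untested is meant among the compounds shown, and "the series" means these compounds.

Three compounds have been measured in a functional assay on TK-10 cells (Homo sapiens) for inhibition, read by sulforhodamine B assay, with a stated time of 48 h; a lower number here means a stronger inhibitor of growth, a higher number a weaker inhibitor of growth:

compound 1 `Nc1cc(N)c2nc(-c3ccccc3)c(NCc3ccc(Cl)c(Cl)c3)nc2c1` — 30200 nM.
compound 2 `CCOC(=O)[C@H](CCC(=O)O)NC(=O)c1ccc(Sc2nc3cc(N)cc(N)c3nc2-c2ccccc2)cc1` — < 100000 nM.
compound 3 `CCOC(=O)[C@H](CCC(=O)O)NC(=O)c1ccc(Oc2nc3cc(N)cc(N)c3nc2-c2ccccc2)cc1` — 17800 nM.

For compound 2 the value recorded is a limit of this assay and not a number (the limit of < 100000 nM in this assay, at which 1 of the 3 values shown sits). Compound 1 and compound 3 sit within the usual scatter of each other, so neither can be called the stronger or weaker inhibitor of growth on these numbers.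

Compound 4 `Nc1cc(N)c2nc(-c3ccccc3)c(NCc3ccc(F)cc3)nc2c1` differs from compound 1 in one place: 4-fluorophenyl in place of 3,4-dichlorophenyl on a saturated chain carbon bound to a nitrogen on an aromatic ring. Among the compounds with values here, no measured pair of compounds differs in exactly this way, so the step has no measured counterpart here. The change is expected to weaken growth inhibition modestly, a step of a 1.5-fold higher number from compound 1 to compound 4 (0.17 log units; within the scatter) in this assay. Compound 4 is therefore estimated at 45000 nM, with a likely range from 15000 nM to 90000 nM.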

Compound 4, concentration for total growth inhibition: 20000 nM
Estimate against measurement, compound 4: 2.3-fold (0.35 log units) above, within the range that was stated.
By their numbers in this assay, from the lowest: compounds 3, 4 and 1 (each within the scatter of the next).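

Within the data shown here, the first measured change at this position, 4-fluorobenzyl in place of 3,4-dichlorobenzyl, is a step of a 1.5-fold lower number from compound 1 to compound 4 (0.18 log units; within the scatter) in this assay. The two groups therefore cannot be told apart on these numbers, and the aromatic ring on this chain carries either substitution with no change beyond the scatter. Nothing given here bears on the reason for this result. The compounds shown leave open whether a plain benzyl group, a longer chain ending in phenyl, or a carboxylic acid on that ring would move the number beyond the scatter.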